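Working notes: aryl exchange on the shared core

A few compounds are considered here, and "the series" means these few. Any claim that something is new, unique, unknown or untested is made for them only; others in the source may bear on it.

Measured so far, in an assay on Sf9 cells for inhibition of protein deacetylase HDAC6 (Homo sapiens), read by fluorescence, with a stated time of 40 min, tested at 100 nM; a lower number here means less inhibition, a higher number more inhibition at the concentration tested (going by the name of the read-out):
compound 1, `O=C(NO)c1ccc(NCc2nc(-c3cccnc3)nn2-c2ccccc2)cc1`, gives 57.7%
compound 2, `CCc1ccc(-n2nc(-c3ccccc3)nc2CNc2ccc(C(=O)NO)cc2)cc1`, gives 38.3%
compound 3, `O=C(NO)c1ccc(NCc2nc(-c3ccccc3)nn2-c2cccc(Cl)c2)cc1`, gives 62.3%

Compound 1 holds the second highest of the three numbers; compound 3 sits within the scatter of it, while compound 2 lies below it beyond the scatter. Compound 4, `CCc1ccc(-c2nc(CNc3ccc(C(=O)NO)cc3)n(-c3ccccc3)n2)cc1`, differs from compound 1 by 4-ethylphenyl in place of pyridin-3-yl on an aromatic carbon. Among the measured compounds shown here, the only measured step, a number 24 percentage points higher from compound 2 to compound 3 (beyond the scatter), concerns the group on the ring nitrogen rather than the ring carbon changed here, so it bears on the present change only loosely; it does show that the compound carrying 4-ethylphenyl, compound 2, gave the lowest number. A modest drop, or none beyond the scatter, is therefore expected, with the step expected to be a number 11.7 percentage points lower from compound 1 to compound 4 (beyond the scatter). Compound 4 is estimated at 46%, in the range 30% to 62%.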

Compound 4, a percentage reported as inhibition, at one concentration (the size of the read-out at that concentration, not a potency): 54.6%
Beside the measured number, compound 4's estimate is 8.6 percentage points below it; the range from low to high includes it.
By their numbers in this assay, from the lowest: compound 2; then compounds 4, 1 and 3 (each within the scatter of the next).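

Exchanging pyridin-3-yl for 4-ethylphenyl on this aromatic carbon gives a number 3.1 percentage points lower from compound 1 to compound 4 (within the scatter) in this assay at the concentration tested. The hetero atom and hydrogen-bond acceptor of pyridin-3-yl are therefore not required at this position for this read-out, and the position accepts the all-carbon ring with its ethyl group. Nothing at hand explains this result.

Still open, going by these compounds, is whether an amine or a carboxylic acid on this aromatic carbon would be accepted in the same way. Also open, on these data alone, is whether a longer chain in place of the ethyl group would move the number.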